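A group swap at the limit of a cell assay

The source may hold more compounds than are shown below. What is called first, only, known or untested is meant among the compounds shown, and "the series" means these compounds.

All three measured compounds in an ADME assay on Raji cells (Homo sapiens) for cytotoxicity, read by luminescence, with a stated time of 72 h (a lower number here means that less compound is needed, a higher number that more compound is needed for the effect), give only a limit of the assay and not a number.
Compound 1 `CCOC(=O)c1c(-c2cccc(F)c2)[nH]c2cc(OC)c(F)cc2c1=O` gives > 21500 nM as a limit
Compound 2 `CCOC(=O)c1c(-c2cccc(Cl)c2)[nH]c2cc(OC)c(F)cc2c1=O` gives > 21500 nM as a limit
Compound 3 `CCOC(=O)c1c(-c2cccc(-c3ccccc3Cl)c2)[nH]c2cc(OC)c(F)cc2c1=O` gives > 21500 nM as a limit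

Compound 3 therefore has no exact place in the series. All that can be said of the measured compounds is that they share one reading, the limit of > 21500 nM in this assay, at which 3 of the 3 values shown sit, and none can be ranked against another.

Compound 4 `CCOC(=O)c1c(-c2cccc(-c3nc(C)c(C)s3)c2)[nH]c2cc(OC)c(F)cc2c1=O` differs from compound 3 in a single group, as follows: 4,5-dimethyl-1,3-thiazol-2-yl in place of 2-chlorophenyl on an aromatic carbon and the swap sits on an aromatic carbon of a six-membered aromatic ring of carbon only.

The measured changes at this same place are a step that the two limits leave unreadable from compound 1 to compound 2 and a step that the two limits leave unreadable from compound 1 to compound 3 and also a step that the two limits leave unreadable from compound 2 to compound 3 and none of them gives a size or a direction. With so little to go on, the expectation rests on all three compounds keeping the same reading in this assay despite their different groups at this place. The expected change is a number no higher from compound 3 to compound 4 (the limit leaves the size open) and no shift beyond the usual scatter is expected. For compound 4 the estimate is 21500 nM with an expected range from 10000 nM to 40000 nM and another limit is the likeliest report.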

Compound 4, half-maximal effective concentration: > 21500 nM
Compound 4 gave a limit, no number; the forecaster's own chance of this, stated with the estimate: 85%; the middle value sits exactly at the limit.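

Among these compounds, compound 4 gives only a limit in this assay, so no step from compound 1, compound 2 or compound 3 to compound 4 can be read, and all four compounds share one reading: the limit of > 21500 nM in this assay, at which 4 of the 4 values shown sit. The compounds shown leave open how they rank against one another, and whether the group at this place affects the reading at all.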